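The source may report more compounds than this note shows. Statements on the series, on what has been measured and on what is new or still open speak of the compounds shown alone.

Measured so far in an assay on HeLa cells with Bile acid receptor (Homo sapiens) as the target, read by a luciferase reporter, with a stated time of 24 h; on this read-out lower numbers stand for an effect already at smaller amounts and higher numbers for an effect only at larger amounts of compound:
compound 1, `CC(NC(=O)c1ccc(C(C)(C)C)cc1)c1ccc(C(=O)O)cc1`: 76 nM
compound 2, `C[S+]([O-])c1ccc(CNC(=O)c2ccc(C(C)(C)C)cc2)cc1`: 1300 nM
compound 3, `CCOc1ccc(CNC(=O)c2ccc(C(C)(C)C)cc2)cc1`: 160 nM

Compound 2 stands highest of the three numbers in this assay. Its nearest neighbour is compound 3, reached by an 8.1-fold lower number from compound 2 to compound 3 (0.91 log units; beyond the scatter); compound 1 lies further off, its value being the lowest of the three.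

Compound 4, `CSc1ccc(CNC(=O)c2ccc(C(C)(C)C)cc2)cc1`, has not yet been measured in this assay. It differs from compound 2 in one place: a group of 2 heavy atoms (1 carbon, 1 sulfur; no ring) in place of a group of 3 heavy atoms (1 carbon, 1 oxygen, 1 sulfur; no ring), on an aromatic carbon. Within the data shown here, the one measured step that bears on this change is an 8.1-fold lower number from compound 2 to compound 3 (0.91 log units; beyond the scatter), in which the same group of 3 heavy atoms (1 carbon, 1 oxygen, 1 sulfur; no ring) left the same aromatic carbon and a group of 3 heavy atoms (2 carbon, 1 oxygen; no ring) entered in its place. The step to compound 4 removes the same group but puts methylsulfanyl there instead, so a lower number is expected, beyond the scatter, though the entering group is a different one and the size may fall short of that step. The expected step is a 5.2-fold lower number from compound 2 to compound 4 (0.72 log units; beyond the scatter). For compound 4 the estimate in this assay is 250 nM, with a range from 80 nM to 800 nM.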

Compound 4, half-maximal effective concentration: 100 nM
For compound 4 the middle estimate is 2.5-fold (0.40 log units) above the measured one; the range from low to high includes it.
By their numbers in this assay, from the lowest: compounds 1, 4 and 3 (each within the scatter of the next, the first and the last beyond it); then compound 2.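

In this assay, a 13-fold lower number from compound 2 to compound 4 (1.11 log units; beyond the scatter) comes from taking only the oxygen off the sulfur, with the methyl and sulfur kept on the same aromatic carbon, para to a large group; the high number of compound 2 therefore goes with that oxygen, and sulfur at this position is compatible with a low number. Methylsulfanyl and ethoxy cannot be told apart here, since a 1.6-fold lower number from compound 3 to compound 4 (0.20 log units; within the scatter) lies within the scatter, so two different groups without the sulfur-bound oxygen give values that cannot be separated. No measured data bear on why the oxygen on sulfur carries this cost.

Among these compounds, still open is whether a sulfur carrying two oxygens on the same aromatic carbon would raise the number further than the single oxygen of compound 2 does, or would behave differently. Also open, on these data alone, is how far this position tolerates other groups, for example an amine or a longer chain such as butoxy, and whether these would stay level with compounds 3 and 4 or move away from them.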